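This account rests on a few compounds, and the source may have more. Where it says the series, first, only, none or still open, it means among the compounds named here.

Values in a functional assay on A549 cells (Homo sapiens) for inhibition, read by sulforhodamine B assay, with a stated time of 48 h; a higher number here means a weaker inhibitor of growth, a lower number a stronger inhibitor of growth:
- compound 1 `COc1ccc(/C=C/C(=O)C(=Cc2cc(OC)c(OC)c(OC)c2)C(=O)/C=C/c2ccc(OC)c(OC)c2)cc1OC`: 230 nM
- compound 2 `COc1ccc(/C=C/C(=O)C(=Cc2cccc(F)c2)C(=O)/C=C/c2ccc(OC)c(OC)c2)cc1OC`: 580 nM
- compound 3 `CCc1ccc(C=C(C(=O)/C=C/c2ccc(OC)c(OC)c2)C(=O)/C=C/c2ccc(OC)c(OC)c2)cc1`: 630 nM

In this assay, compound 3 gives 630 nM and cannot be separated from compound 2, with a 1.1-fold higher number from compound 2 to compound 3 (0.04 log units; within the scatter). Against compound 1 the gap is real but modest, with a 2.7-fold higher number from compound 1 to compound 3 (0.44 log units; beyond the scatter).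

Compound 4 `COc1ccc(/C=C/C(=O)C(=CO)C(=O)/C=C/c2ccc(OC)c(OC)c2)cc1OC` carries hydroxy in place of 4-ethylphenyl on a double-bonded chain carbon bound to a double-bonded chain carbon.

The nearest evidence is a 2.5-fold higher number from compound 1 to compound 2 (0.40 log units; beyond the scatter), together with a 2.7-fold higher number from compound 1 to compound 3 (0.44 log units; beyond the scatter) and a 1.1-fold higher number from compound 2 to compound 3 (0.04 log units; within the scatter). All three exchange one aromatic ring for another, so none of them measures loss of the ring. These steps are small, and they leave the size of the present change uncertain. A move towards a higher number, meaning weaker growth inhibition, is expected, somewhat larger than the measured steps.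

The expected change is a 2.4-fold higher number from compound 3 to compound 4 (0.38 log units; beyond the scatter).

For compound 4 the estimated value is 1500 nM, with an expected range of 400 nM to 6000 nM.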

Compound 4, concentration for 50% growth inhibition: > 25000 nM
Compound 4: only a limit was reported (the forecaster's own chance of this, stated with the estimate: 5%); middle value at least 16-fold (1.22 log units) from the limit.
By their numbers in this assay, from the lowest: compound 1; then compounds 2 and 3 (each within the scatter of the next). At a limit, above all of these: compound 4.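

In this assay compound 4 is reported only as a limit, not as a number: the limit of > 25000 nM in this assay, at which 1 of the 4 values shown sits.

The earlier steps shown here only exchanged one aromatic ring for another, whereas hydroxy on this double-bonded chain carbon removes the ring altogether and gives an at least 39-fold higher number from compound 3 to compound 4 (1.59 log units; beyond the scatter) and an at least 43-fold higher number from compound 2 to compound 4 (1.63 log units; beyond the scatter) and an at least 100-fold higher number from compound 1 to compound 4 (2.03 log units; beyond the scatter). All three steps are bounds rather than sizes, and each is far larger than any step among compound 1, compound 2 and compound 3, so in these four compounds the choice of aromatic ring matters much less than having one here.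

With hydroxy as the only non-aromatic group shown, the loss of the ring cannot be separated from the entry of hydroxy. Methyl or an amine on the same carbon would separate the two, and the true value of compound 4 remains open.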